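Swapping a methoxy for a fluoro on the amide ring

This account rests on a few compounds, and the source may have more. Where it says the series, first, only, none or still open, it means among the compounds named here.

Compound 2 `COc1cccc(C(=O)NCc2ccc(CNS(=O)(=O)c3ccc(C)cc3)cc2)c1` is the sulfonamide-amide with the lowest number of the three measured compounds: in an assay on MDA-MB-231 cells for binding affinity to C-X-C chemokine receptor type 4 (Homo sapiens), read by immunofluorescence and microscopy, with stated times of 10 min and 30 min (on this read-out higher numbers stand for an effect only at larger amounts of compound and lower numbers for an effect already at smaller amounts), compound 2 gives 10 nM. Compound 1 `O=C(NCc1ccc(CNS(=O)(=O)c2ccccc2)cc1)c1ccc(F)cc1` gives 100 nM, and compound 3 `O=C(NCc1ccc(CNS(=O)(=O)c2ccccc2)cc1)c1ccccc1F` gives 1000 nM in this assay. Compound 4 `Cc1ccc(S(=O)(=O)NCc2ccc(CNC(=O)c3cccc(F)c3)cc2)cc1` differs from compound 2 only in one place: fluoro in place of methoxy on an aromatic carbon. Within the data shown here, no measured pair shows this change itself; the only step, a 10-fold higher number from compound 1 to compound 3 (1.00 log units; beyond the scatter), moves a fluoro from one position to another on the same ring and says that the amide-ring substituent matters. A modest loss is therefore expected for compound 4, a 3.0-fold higher number from compound 2 to compound 4 (0.48 log units; beyond the scatter). Compound 4 is estimated at 30 nM in this assay, most likely between 10 nM and 150 nM.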

Compound 4, effective concentration (reported as EC, without a stated level of effect): 1 nM
Estimate against measurement, compound 4: 30-fold (1.48 log units) above; the measured number lies below the stated range.
By their numbers in this assay, from the lowest: compound 4; then compound 2; then compound 1; then compound 3.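

The methoxy is not needed at this place on the amide ring: with 3-fluorophenyl in place of 3-methoxyphenyl, this assay shows a 10-fold lower number from compound 2 to compound 4 (1.00 log units; beyond the scatter) in the number. A single fluorine atom thus does better here than the two heavy atoms of the methoxy, and the hydrogen-bond acceptor counted on the methoxy can go with no loss. Nothing available explains this gain. Still open, from the compounds shown here alone, is how a chloro, a hydroxyl or an amine at this same place would move the number.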